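Sulfonyl aryl change in the indol-6-yl series

This account rests on a few compounds, and the source may have more. Where it says the series, first, only, none or still open, it means among the compounds named here.

Compound 1 `Cn1c(=O)c(S(=O)(=O)c2ccc(F)cc2F)cc2cnc(Nc3ccc4cc[nH]c4c3)nc21` stands highest of the two numbers in a functional assay on DU-145 cells (Homo sapiens) for inhibition, read by trypan blue exclusion, with a stated time of 72 h (a higher number here means a weaker inhibitor, a lower number a stronger inhibitor), where compound 1 gives 5000 nM. Its nearest neighbour is compound 2 `Cn1c(=O)c(S(=O)(=O)c2ccc(F)cc2F)cc2cnc(Nc3cccc4[nH]ccc34)nc21`, which in this assay gives 750 nM; that step, a 6.7-fold lower number from compound 1 to compound 2 (0.82 log units; beyond the scatter), concerns only 1H-indol-4-yl in place of 1H-indol-6-yl on a nitrogen on an aromatic ring. Compound 3 `Cn1c(=O)c(S(=O)(=O)c2ccccc2)cc2cnc(Nc3ccc4cc[nH]c4c3)nc21` differs from compound 1 elsewhere: phenyl in place of 2,4-difluorophenyl on a sulfonyl sulfur. For the measured compounds named here, no measured step touches the (2,4-difluorophenyl)sulfonyl group, so nothing among the measured compounds argues for a move beyond the scatter in this assay. For compound 3 the expected value is 5000 nM, with a range from 1500 nM to 16000 nM, an expected step of no change at the digits printed from compound 1 to compound 3 (within the scatter).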

Compound 3, half-maximal inhibitory concentration: 10000 nM
Compound 3: the middle estimate sits 2.0-fold (0.30 log units) below what was measured; the range from low to high includes it.
By their numbers in this assay, from the lowest: compound 2; then compounds 1 and 3 (each within the scatter of the next).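

On the sulfonyl sulfur, phenyl in place of 2,4-difluorophenyl gives a 2.0-fold higher number from compound 1 to compound 3 (0.30 log units; within the scatter) in this assay. For the compounds shown here, this is the first step read at this position, and it shows that, with the 1H-indol-6-yl group in place, the two fluorines can go without a change beyond the scatter. No evidence on hand accounts for this result.

Still open, as far as these compounds go, is whether the same change reads alike with the 1H-indol-4-yl group of compound 2. Also open, from the compounds shown here alone, is whether an amine or a carboxylic acid on the sulfonyl phenyl would move the number.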